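Sulfonamide for amide on the smaller-lactam core

This account rests on a few compounds, and the source may have more. Where it says the series, first, only, none or still open, it means among the compounds named here.

Compound 1 `CCC(=O)N[C@@H]1CCCc2c1cncc2N1CCc2cc(Cl)ccc2C1=O` gives 3330 nM in an ADME assay on cells for inhibition of cytochrome P450 11B1, mitochondrial (Homo sapiens), read by HTRF; a lower number here means a stronger inhibitor, a higher number a weaker inhibitor. Compound 2 `CS(=O)(=O)N[C@@H]1CCCc2c1cncc2N1CCc2cc(Cl)ccc2C1=O` differs from it by methylsulfonyl in place of propanoyl on an amine nitrogen; in this assay compound 2 gives 5150 nM, and the step of a 1.5-fold higher number from compound 1 to compound 2 (0.19 log units; within the scatter). Compound 3 `CCC(=O)N[C@@H]1CCCc2c1cncc2N1Cc2cc(Cl)ccc2C1=O` carries the propanoyl group on a different core; the difference between the two cores is not broken down here. In this assay compound 3 gives 5210 nM, a number within the scatter of both compound 1 and compound 2. Compound 4 `CS(=O)(=O)N[C@@H]1CCCc2c1cncc2N1Cc2cc(Cl)ccc2C1=O` repeats the same change on the core of compound 3, (methylsulfonyl in place of propanoyl on an amine nitrogen). Because the earlier step of a 1.5-fold higher number from compound 1 to compound 2 (0.19 log units; within the scatter) stayed within the scatter, a step of similar size is expected here, a 1.3-fold higher number from compound 3 to compound 4 (0.12 log units; within the scatter). Compound 4 is accordingly estimated at 6800 nM in this assay, with a likely range from 3000 nM to 15000 nM.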

Compound 4, half-maximal inhibitory concentration: 9350 nM
The estimate for compound 4 lay 1.4-fold (0.14 log units) below the measured number, within the range that was stated.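

In this assay methylsulfonyl in place of propanoyl on an amine nitrogen gives a 1.8-fold higher number from compound 3 to compound 4 (0.25 log units; within the scatter). Set beside the same change on the other core, the two steps agree: the same change on two cores in this assay, a 1.5-fold higher number (0.19 log units; within the scatter) from compound 1 to compound 2 and a 1.8-fold higher number (0.25 log units; within the scatter) from compound 3 to compound 4, 1.2-fold (0.06 log units) apart, within the scatter of two such steps. On these two cores the change therefore carries over with no difference that can be told from the scatter, but each step is itself within the scatter, so this shows no firm effect of the change and nothing about any further core.

The compounds shown leave open whether a urea, a carbamate or a longer sulfonyl chain on the same nitrogen would move the number beyond the scatter. They also leave open how the change behaves when the chloro group on the core is replaced by another group, such as fluoro or methoxy.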